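The source may report more compounds than this note shows. Statements on the series, on what has been measured and on what is new or still open speak of the compounds shown alone.

Compound 2 `CNC(=O)c1cc(Oc2ccc(NC(=O)c3cc(-c4ccc(F)cc4)ncn3)cc2)ccn1` carries a 4-fluorophenyl group on the shared core. In a functional assay on A549 cells (Homo sapiens) for cytotoxicity, read by MTT assay, with a stated time of 72 h (a lower number here means a stronger inhibitor, a higher number a weaker inhibitor), compound 2 gives > 100000 nM, which is a limit of the assay rather than a measured number. Compound 1 `CNC(=O)c1cc(Oc2ccc(NC(=O)c3cc(-c4ccc(F)cc4)ncn3)cc2F)ccn1` gives > 100000 nM, again only a limit. Compound 3 `CNC(=O)c1cc(Oc2ccc(NC(=O)c3cc(-c4ccc(C(F)(F)F)cc4)ncn3)cc2F)ccn1` gives > 100000 nM, also a limit. Compound 4 `CNC(=O)c1cc(Oc2ccc(NC(=O)c3cc(-c4ccc(Br)cc4)ncn3)cc2)ccn1` has not yet been measured; it differs from compound 2 by bromo in place of fluoro on an aromatic carbon. Within the data shown here, two measured steps concern the same kind of change, a swap of one small substituent on an aromatic ring. The step that the two limits leave unreadable from compound 1 to compound 2 and the step that the two limits leave unreadable from compound 1 to compound 3 both remain unreadable because the limit of > 100000 nM in this assay, at which 3 of the 3 values shown sit, leaves no room to see a gain or a loss in either direction. Among the measured compounds shown here, no measured step therefore points anywhere, and no change beyond the scatter can be expected from the swap. Compound 4 is expected to stay at the same limit, and the estimate for compound 4 is 150000 nM, with a range from 50000 nM to 500000 nM. The expected step that the limit leaves unreadable from compound 2 to compound 4 thus means no readable change.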

Compound 4, half-maximal inhibitory concentration: > 100000 nM
Compound 4: only a limit was reported (the forecaster's own chance of this, stated with the estimate: 85%); the middle value does not contradict the limit.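

Going by these compounds, compound 2 and compound 4 each give only a limit of the assay rather than a measured number, so the change from 4-fluorophenyl to 4-bromophenyl cannot be read, because everything shown sits at one value: the limit of > 100000 nM in this assay, at which 4 of the 4 values shown sit. Whether any change to the shared core would give a measurable value in this assay remains open.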